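Swapping a phenyl for a hydroxyethyl chain on the ring nitrogen

The source may report more compounds than this note shows. Statements on the series, on what has been measured and on what is new or still open speak of the compounds shown alone.

Measured compounds:
Compound 1 `CC1(C)CC(=O)C2=C(C1)N(c1ccccc1)N=C(c1ccccc1)C2` — "not active" (no number reported)
Compound 2 `CCN(CC)CCN1N=C(c2ccc(Br)cc2)CC2=C1CC(C)(C)CC2=O` — 26%

Compound 1 `CC1(C)CC(=O)C2=C(C1)N(c1ccccc1)N=C(c1ccccc1)C2` was tested in a functional assay on the whole organism (Central nervous system, strain CF) for inhibition, with Mus musculus as the target, with a stated time of 15 min, at a dose of 500 mg/kg by the oral route (on this read-out higher numbers stand for more inhibition at the one dose given (going by the name of the read-out) and lower numbers for less inhibition), and gave "not active" (no number reported), which is a word rather than a number, so compound 1 has no measured value to stand on. Compound 2 `CCN(CC)CCN1N=C(c2ccc(Br)cc2)CC2=C1CC(C)(C)CC2=O` carries a diethylaminoethyl chain on the same ring nitrogen, and in this assay compound 2 gives 26%. Going by the values given here, the two results together suggest only that the chain-bearing compound reaches a measurable level while the phenyl-bearing one does not.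

Compound 3 `CC1(C)CC(=O)C2=C(C1)N(CCO)N=C(c1ccccc1)C2`, still untested, differs from compound 1 in one place: 2-hydroxyethyl in place of phenyl on an amine nitrogen in a ring. For this step in this assay a small rise from an unmeasurable starting point is expected, on the order of what compound 2 shows, not a large one. Compound 3 is estimated to give 15%, within a range from 0% to 40%.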

Compound 3, a percentage reported as inhibition, in the whole organism at one dose (the size of the read-out at that dose, not a potency): 1%
For compound 3 the middle estimate is 14 percentage points above the measured one, and the stated range covers the measured number.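

No step can be read between compound 1 and compound 3, since in this assay compound 1 gives "not active" (no number reported) and that is a word rather than a number. The compounds shown leave open how 2-hydroxyethyl compares with phenyl on this read-out. No evidence here bears on the result.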